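Chloro in Place of Amino and Cytotoxicity

This account rests on a few compounds, and the source may have more. Where it says the series, first, only, none or still open, it means among the compounds named here.

In an ADME assay on L1210/0 cells (Mus musculus) for cytotoxicity, with a stated time of 48 h (on this read-out lower numbers stand for stronger inhibition and higher numbers for weaker inhibition), three compounds have been measured.
Compound 1 `Nc1nc(Cl)c2nnn([C@H]3CCCC[C@H]3CO)c2n1` gives 95500 nM.
Compound 2 `Nc1nc(N)c2nnn([C@H]3CCCC[C@H]3CO)c2n1` gives only a limit of the assay, > 200000 nM.
Compound 3 `CC(O)Cn1cnc2c(N)nc(I)nc21` likewise gives only a limit of the assay, > 200000 nM.

Compound 4 `CC(O)Cn1cnc2c(Cl)nc(I)nc21` has not yet been measured in this assay. The measured change chloro in place of amino on an aromatic carbon produced an at least 2.0-fold lower number from compound 2 to compound 1 (0.32 log units; beyond the scatter). The change from compound 3 to compound 4 is chloro in place of amino on an aromatic carbon; it is the same kind of change, though here the place is meta to an iodo group rather than meta to an amino group. The difference between the two cores is not broken down here. Two of the three measured values sit at the limit of > 200000 nM in this assay, at which 2 of the 3 values shown sit. For compound 4 a step resembling the earlier one is expected, estimated as an at least 2.0-fold lower number from compound 3 to compound 4 (0.30 log units; that floor lies within the scatter). Compound 4 is therefore estimated at 100000 nM, expected to lie between 30000 nM and 300000 nM.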

Compound 4, half-maximal inhibitory concentration: > 200000 nM
Compound 4: no number, only a limit; the forecaster's own chance of this, stated with the estimate: 40%; at least 2.0-fold (0.30 log units) between middle value and limit.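

The step from compound 3 to compound 4 cannot be read, since both compounds give only a limit in this assay: the limit of > 200000 nM in this assay, at which 3 of the 4 values shown sit.

As far as these compounds go, whether chloro in place of amino on an aromatic carbon changes the number on the core of compound 3 stays open.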